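Methyl on the phenyl ring of compound 2

The source may report more compounds than this note shows. Statements on the series, on what has been measured and on what is new or still open speak of the compounds shown alone.

Two compounds of the series have been run in a functional assay on the whole organism with Rattus norvegicus as the target, at a dose of 3 mg/kg by the oral route; on this read-out lower numbers stand for a weaker effect and higher numbers for a stronger effect at the one dose given. Compound 2 `CCCCc1cc(C(=O)Nc2nn[nH]n2)nc(-c2ccccc2)c1` gives 71% in this assay. Compound 1 `Cc1cccc(-c2cc(C)cc(C(=O)Nc3nn[nH]n3)n2)c1` gives 61% in this assay, and the two numbers lie within the usual scatter of each other, so no order between them is read. Compound 3 `CCCCc1cc(C(=O)Nc2nn[nH]n2)nc(-c2cccc(C)c2)c1` is not yet measured. It differs from compound 2 in one place: methyl in place of hydrogen on an aromatic carbon. Going by the values given here, no measured pair in this set isolates that change, so there is no step to lean on. With nothing shown beyond the scatter between the two measured compounds, the expected step from compound 2 to compound 3 in this assay is a number 1 percentage points lower from compound 2 to compound 3 (within the scatter), that is, none beyond the scatter. Compound 3 is therefore estimated at 70% in this assay, with a range from 50% to 85%.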

Compound 3, a percentage reported as inhibition, in the whole organism at one dose (the size of the read-out at that dose, not a potency): 82%
For compound 3 the middle estimate is 12 percentage points below the measured one, within the range that was stated.
By their numbers in this assay, from the lowest: compounds 1 and 2 (each within the scatter of the next); then compound 3.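

In this assay, methyl in place of hydrogen on the aromatic carbon, meta to a large group, gives a step beyond the scatter, a number 11 percentage points higher from compound 2 to compound 3 (beyond the scatter), so phenyl to 3-methylphenyl is a change this read-out can register at the one dose given. With the 3-methylphenyl group held constant, propyl in place of hydrogen on the saturated chain carbon also registers, a number 21 percentage points higher from compound 1 to compound 3 (beyond the scatter), and compound 3 stands beyond the scatter of both neighbours. The data available give no measured reason for either step.

As far as these compounds go, whether a chlorine atom or a methoxy group at the same ring place would match methyl remains open. So does whether a chain longer than butyl would hold the effect alongside the 3-methylphenyl group.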